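Cytotoxicity notes on an azo-linked quinolizidine series

This account rests on a few compounds, and the source may have more. Where it says the series, first, only, none or still open, it means among the compounds named here.

Measured so far:
compound 1, `Brc1cccc(/N=N/N2CCCCC2)c1`: > 100000 nM
compound 2, `Cc1c(/N=N/c2cccc(C(F)(F)F)c2)ccc(NC[C@@H]2CCCN3CCCC[C@H]23)c1C`: 52000 nM

Among the compounds with values here, in an ADME assay on MDBK cells (Bos taurus) for cytotoxicity, read by MTT assay, with a stated time of 96 h (a lower number here means that less compound is tolerated, a higher number that more compound is tolerated), compound 2 gives 52000 nM, which is the only plain number in the set. For compound 1 the result of > 100000 nM is a limit of the assay, not a number; this is the situation recorded as the limit of > 100000 nM in this assay, at which 1 of the 2 values shown sits. Within the data shown here, compound 2 therefore stands alone as the one compound of the pair with a measured half-maximal cytotoxic concentration, and nothing in the set ranks it against another measured value.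

The next compound is compound 3, `Cc1c(/N=N/c2ccccc2)ccc(NC[C@@H]2CCCN3CCCC[C@H]23)c1C`. It differs from compound 2 in one place: hydrogen in place of trifluoromethyl on an aromatic carbon. Among the measured compounds shown here, no step between two measured compounds exists here to calibrate this change, so the expectation rests on compound 2 alone. The loss of the trifluoromethyl group is expected to move the value little, if at all, beyond the scatter; a step from compound 2 to compound 3 of about a 1.3-fold higher number from compound 2 to compound 3 (0.13 log units; within the scatter) is expected, leaning toward better tolerance. Compound 3 is thus estimated at 70000 nM, within 30000 nM to 150000 nM, with a fair chance that the assay reports only a limit.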

Compound 3, half-maximal cytotoxic concentration: 48000 nM
Compound 3: middle estimate off by 1.5-fold (0.16 log units), on the high side; the measured number falls inside the stated range.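

In this assay, the exchange of 3-(trifluoromethyl)phenyl for phenyl gives a 1.1-fold lower number from compound 2 to compound 3 (0.03 log units; within the scatter), so compound 2 and compound 3 cannot be told apart on this read-out. Within the data shown here, this is the first step that can be read between two measured compounds, and for this pair, the half-maximal cytotoxic concentration does not depend on trifluoromethyl at this position, on an aromatic carbon meta to a large group. No measurement in the set bears on why the two values fall within the scatter of each other.

With only hydrogen and trifluoromethyl shown at this position, it remains open whether an amine or a carboxylic acid on the same aromatic carbon would give a step beyond the scatter. A single pair also leaves open whether the same exchange would read the same way on a different core, so this result applies only to compound 2 and compound 3.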